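The compounds below may be only part of what the source reports. "The series", "measured", "known", "first", "only" and "open" are said of these compounds alone.

Measured so far in an ADME assay on Raji cells (Homo sapiens) for cytotoxicity, read by luminescence, with a stated time of 72 h; on this read-out higher numbers stand for an effect only at larger amounts of compound and lower numbers for an effect already at smaller amounts:
- Compound 1 `CCOC(=O)c1c(-c2cccc(OC(C)C)c2)[nH]c2cc(OC)ccc2c1=O`: > 21500 nM
- Compound 2 `CCOC(=O)c1c(-c2cccc(OCc3ccccc3)c2)[nH]c2cc(OC)ccc2c1=O`: > 21500 nM

Neither entry is a true number. Compound 2 stands at > 21500 nM, which is a limit of the assay. Compound 1 also gives a limit, > 21500 nM. Together they make up all the evidence so far: the limit of > 21500 nM in this assay, at which 2 of the 2 values shown sit.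

The next compound, compound 3 `CCOC(=O)c1c(-c2cccc(Oc3ccccc3)c2)[nH]c2cc(OC)ccc2c1=O`, differs from compound 2 in one group: phenyl in place of benzyl on an oxygen on an aromatic ring. Put simply, benzyloxy becomes phenoxy, with phenyl in place of benzyl on an oxygen on an aromatic ring, and the rest of the molecule stays the same.

Among the compounds with values here, only one measured change bears on this, as it falls on the same oxygen, going from isopropyl to benzyl: a step that the two limits leave unreadable from compound 1 to compound 2. Its size and direction are both hidden. Resting on that step and on (the limit of > 21500 nM in this assay, at which 2 of the 2 values shown sit), no step beyond the usual scatter is expected in this assay, and neither direction is favoured. The expected result is a step that the limit leaves unreadable from compound 2 to compound 3. Another limit is the most likely report. For compound 3 the estimated value is 25000 nM, with an expected range from 12000 nM to 50000 nM.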

Compound 3, half-maximal effective concentration: > 21500 nM
Compound 3: a limit, no number; the forecaster's own chance of this, stated with the estimate: 85%; the middle value does not contradict the limit.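

Compound 3 gives > 21500 nM in this assay, which is again a limit and not a number. Within the data shown here, no step among compound 1, compound 2 and compound 3 can therefore be read. What stays open is where each of these compounds truly lies, and so whether isopropyl, benzyl and phenyl on this oxygen differ at all.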